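From an Amino Ester to a Cyclohexyl Amine

The compounds below may be only part of what the source reports. "The series", "measured", "known", "first", "only" and "open" are said of these compounds alone.

In a functional assay on MCF7 cells (Homo sapiens) for antiproliferative activity (a higher number here means a weaker inhibitor, a lower number a stronger inhibitor), compound 1 (`CC(C)=CCc1cc(C(=O)Nc2cc3ccc(OCCCN4CCCC4)c(C)c3oc2=O)ccc1O`) gives 990 nM. For the measured compounds named here, compound 2 (`COC(=O)CNCCCOc1ccc2cc(NC(=O)c3ccc(O)c(CC=C(C)C)c3)c(=O)oc2c1C`) gives 2820 nM, the higher of the two numbers so far, which makes it the weaker inhibitor of the pair. Going by the values given here, the one measured step, a 2.8-fold higher number from compound 1 to compound 2 (0.45 log units; beyond the scatter), is modest but beyond the scatter. It puts ((methoxycarbonyl)methyl)amino in place of pyrrolidin-1-yl on a saturated chain carbon, three bonds along the chain from an oxygen on an aromatic ring.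

Compound 3 (`CC(C)=CCc1cc(C(=O)Nc2cc3ccc(OCCCNC4CCCCC4)c(C)c3oc2=O)ccc1O`) has not yet been measured. It carries cyclohexyl in place of (methoxycarbonyl)methyl on an amine nitrogen. The methoxycarbonyl group goes and a non-aromatic ring returns to the end of the chain, as in compound 1 at 990 nM. Among the compounds with values here, no measured compound carries cyclohexylamino, so that single step is the only guide, and it suggests a partial return towards the lower number. The expected change is a 1.9-fold lower number from compound 2 to compound 3 (0.27 log units; within the scatter), a modest step at most. Compound 3 is estimated at 1500 nM, with an expected range of 500 nM to 4500 nM.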

Compound 3, half-maximal inhibitory concentration: 1070 nM
Estimate against measurement, compound 3: 1.4-fold (0.15 log units) above; low and high end bracket the measured number.
By their numbers in this assay, from the lowest: compounds 1 and 3 (each within the scatter of the next); then compound 2.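

Replacing the ester-bearing group with cyclohexyl on the amine nitrogen gives a 2.6-fold lower number from compound 2 to compound 3 (0.42 log units; beyond the scatter), so the loss seen with (methoxycarbonyl)methyl on this chain end is recovered in this single change. The comparison with the pyrrolidin-1-yl compound gives a 1.1-fold higher number from compound 1 to compound 3 (0.03 log units; within the scatter), so in this assay the two compounds cannot be told apart, even though the ring in compound 1 contains the amine nitrogen and the ring in compound 3 is attached to it as cyclohexylamino. At this position, three bonds along the chain from an oxygen on an aromatic ring, these two non-aromatic ring amines therefore read alike, while the open-chain amino ester of compound 2 stands apart from both; no information bearing on the reason for this accompanies the result.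

The change from compound 2 to compound 3 removes the methoxycarbonyl group and adds a ring in one step, so these compounds cannot show which of the two matters, and an open-chain hexylamino group or the carboxylic acid in place of the methyl ester would pull them apart. As far as these compounds go, how far this tolerance extends also remains open, for example to a morpholine ring, a phenyl ring on the amine, or a longer chain.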